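Shared core, varied amine on the benzyl carbon

The source may report more compounds than this note shows. Statements on the series, on what has been measured and on what is new or still open speak of the compounds shown alone.

Measured compounds:
compound 1, `COc1ccc(/C=C\c2cc(OC)c(OC)c(OC)c2)cc1OCc1ccc(CN2CC[C@H](O)C2)cc1`, 7200 nM;
compound 2, `COc1ccc(/C=C\c2cc(OC)c(OC)c(OC)c2)cc1OCc1ccc(CN2CCCCC2C(=O)NCCNC(=O)OC(C)(C)C)cc1`, 1900 nM.

For the measured compounds named here, in a functional assay on MC-38 cells (Mus musculus) for antiproliferative activity, read by CCK-8 assay, with a stated time of 48 h (a higher number here means a weaker inhibitor, a lower number a stronger inhibitor), compound 1 stands at the highest number of the two measured compounds; its only neighbour, compound 2, reads at a lower number, and that gap lies beyond the scatter of repeated runs. Going by the values given here, no single-point step between the two measured compounds exists, so the two values are compared only as they stand.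

Compound 3, `COc1ccc(/C=C\c2cc(OC)c(OC)c(OC)c2)cc1OCc1ccc(CNC(C)(C)C(=O)O)cc1`, is unmeasured. Set against compound 1, the change is (1-carboxy-1-methylethyl)amino in place of 3-hydroxypyrrolidin-1-yl on a saturated chain carbon bound to an aromatic carbon. The ring leaves, a chain with a carboxylic acid enters, and the count of hydrogen-bond donors rises by one.

Nothing measured touches an acid on this benzyl carbon, so the step from compound 1 to compound 3 is set at about none beyond the scatter, with the wider uncertainty placed on the side of a higher number. The step is expected as a 1.3-fold higher number from compound 1 to compound 3 (0.10 log units; within the scatter). Compound 3 is therefore estimated at 9000 nM, within 3000 nM to 30000 nM.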

Compound 3, half-maximal inhibitory concentration: > 10000 nM
Compound 3: a limit, no number (the forecaster's own chance of this, stated with the estimate: 10%); middle value at least 1.1-fold (0.04 log units) away from the limit.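

In this assay compound 3 reads > 10000 nM, which is a limit of the assay and not a number. For the compounds shown here, with (1-carboxy-1-methylethyl)amino in place of 3-hydroxypyrrolidin-1-yl on a saturated chain carbon bound to an aromatic carbon, the step reads an at least 1.3-fold higher number from compound 1 to compound 3 (0.14 log units; that floor lies within the scatter); this is the first reading of an open chain carrying a carboxylic acid at this position, and it shows no gain over the ring of compound 1, while its floor alone does not separate the two compounds. The real size of the step stays unfixed because the reading of compound 3 ends at the top of the measured range: the limit of > 10000 nM in this assay, at which 1 of the 3 values shown sits.

In this one step the ring leaves and the carboxylic acid enters together, so the compounds shown leave open which of the two goes with the reading. A methyl ester in place of the carboxylic acid, or an open-chain amine with no acid on it, would pull the two apart, and either could also show whether this position tolerates an open chain at all.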